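This account rests on a few compounds, and the source may have more. Where it says the series, first, only, none or still open, it means among the compounds named here.

Measured in a functional assay on MGC-803 cells (Homo sapiens) for inhibition, read by MTT assay, with a stated time of 72 h; on this read-out lower numbers stand for stronger inhibition and higher numbers for weaker inhibition:
- Compound 1 `Cc1cc(N2CC[C@@H](C)[C@@H](N(C)c3ncnc4[nH]ccc34)C2)n2ncnc2n1`: 4350 nM
- Compound 2 `Cc1cc(N2CC[C@@H](C)[C@@H](N(C)c3ncnc4[nH]ccc34)C2)n2nc(SCc3csc4ccc(Cl)cc34)nc2n1`: > 100000 nM, a limit of the assay
- Compound 3 `Cc1ccc(CSc2nc3nc(C)cc(N4CC[C@@H](C)[C@@H](N(C)c5ncnc6[nH]ccc56)C4)n3n2)cc1`: 5860 nM

Within the data shown here, compound 3 stands level with the unsubstituted parent, the step of a 1.3-fold higher number from compound 1 to compound 3 (0.13 log units; within the scatter) lying within the scatter, and it has the higher of only two true numbers because the result for compound 2 is a limit.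

Compound 4 `Cc1cc(N2CC[C@@H](C)[C@@H](N(C)c3ncnc4[nH]ccc34)C2)n2nc(SCc3cc(Cl)ccc3Cl)nc2n1` differs from compound 3 by one change, 2,5-dichlorophenyl in place of 4-methylphenyl on a saturated chain carbon bound to a sulfur.

Among the measured compounds shown here, three measured steps concern this part of the molecule. The (4-methylbenzyl)sulfanyl group gave only the small step already noted, whereas the large step of an at least 22-fold higher number from compound 1 to compound 2 (1.36 log units; beyond the scatter) came with the ((5-chloro-1-benzothiophen-3-yl)methyl)sulfanyl group. The equally large step an at least 17-fold lower number from compound 2 to compound 3 (1.23 log units; beyond the scatter) shows that the group on the sulfur can matter. That step involves a chlorine-bearing group, as does the entering 2,5-dichlorophenyl, so a moderate rise is expected, well short of those large steps. The expected change is a 1.9-fold higher number from compound 3 to compound 4 (0.27 log units; within the scatter), and it may not clear the scatter by much. Compound 4 is estimated at 11000 nM, with an expected range of 3000 nM to 60000 nM.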

Compound 4, half-maximal inhibitory concentration: 9850 nM
Compound 4: the middle estimate sits 1.1-fold (0.05 log units) above what was measured; low and high end bracket the measured number.
By their numbers in this assay, from the lowest: compounds 1, 3 and 4 (each within the scatter of the next, the first and the last beyond it). At a limit, above all of these: compound 2.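

In this assay the change from 4-methylbenzyl to 2,5-dichlorobenzyl stays within the scatter (a 1.7-fold higher number from compound 3 to compound 4 (0.23 log units; within the scatter)), so chlorine on the phenyl does not in itself go with the large rise seen for compound 2. Against the unsubstituted parent, the (2,5-dichlorobenzyl)sulfanyl group gives a modest step beyond the scatter (a 2.3-fold higher number from compound 1 to compound 4 (0.35 log units; beyond the scatter)), whereas the (4-methylbenzyl)sulfanyl group of compound 3 stays within it. The step (an at least 10-fold lower number from compound 2 to compound 4 (1.00 log units; beyond the scatter)) sets 2,5-dichlorophenyl well apart from 5-chloro-1-benzothiophen-3-yl, but its size is only a bound, since the result for compound 2 is a limit: the limit of > 100000 nM in this assay, at which 1 of the 4 values shown sits.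

The compounds shown leave open what a single chlorine on the phenyl would do. They also do not tell whether an amine or a carboxylic acid on the phenyl, or a longer chain carrying it on the sulfur, would give a lower number than the parent.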